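The compounds below may be only part of what the source reports. "The series", "measured", "known", "first", "only" and "open" are said of these compounds alone.

Compound 1 (`c1ccc(-c2cc(-c3ccsc3)cc(-c3ccccn3)n2)nc1`), compound 2 (`c1ccc(-c2cc(-c3ccco3)cc(-c3ccccn3)n2)nc1`) and compound 3 (`c1ccc(-c2cc(-c3ccoc3)cc(-c3ccccn3)n2)nc1`) share one core and differ only in a single five-membered ring. In a functional assay on SK-OV-3 cells (Homo sapiens) for antiproliferative activity (a higher number here means a weaker inhibitor of growth, a lower number a stronger inhibitor of growth), compound 1 gives 0.1 ug/mL and compound 2 gives 0.13 ug/mL while compound 3 gives 0.6 ug/mL and so has the highest number of the three, making it the weakest growth inhibitor among them. Compound 4 (`c1ccc(-c2cc(-c3cccs3)cc(-c3ccccn3)n2)nc1`) puts thiophen-2-yl in place of the furan-3-yl of compound 3 on an aromatic carbon (thiophen-2-yl in place of furan-3-yl on an aromatic carbon). Among the measured compounds shown here, three measured steps bear on this change. Arriving at furan-3-yl from thiophen-3-yl brought a 6.0-fold higher number from compound 1 to compound 3 (0.78 log units; beyond the scatter) and arriving at it from furan-2-yl brought a 4.6-fold higher number from compound 2 to compound 3 (0.66 log units; beyond the scatter) and both are modest, whereas furan-2-yl in place of thiophen-3-yl brought a 1.3-fold higher number from compound 1 to compound 2 (0.11 log units; within the scatter) and no real shift. Thiophen-2-yl shares its ring with the thiophen-3-yl of compound 1 and its numbering with the furan-2-yl of compound 2, so a modest move back to a lower number is expected in this assay for this swap. The expected step is a 4.0-fold lower number from compound 3 to compound 4 (0.60 log units; beyond the scatter) and carries real uncertainty. Compound 4 is estimated at 0.15 ug/mL (range 0.05 ug/mL to 0.5 ug/mL).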

Compound 4, concentration for 50% growth inhibition: 0.12 ug/mL
Estimate against measurement, compound 4: 1.3-fold (0.10 log units) above; the measured number falls inside the stated range.
By their numbers in this assay, from the lowest: compounds 1, 4 and 2 (each within the scatter of the next); then compound 3.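

In this assay, thiophen-2-yl in place of furan-3-yl brings a modest return to a low number (a 5.0-fold lower number from compound 3 to compound 4 (0.70 log units; beyond the scatter)), which leaves the furan-3-yl group of compound 3 as the only outlier of the four. Thiophen-2-yl cannot be told apart from thiophen-3-yl (a 1.2-fold higher number from compound 1 to compound 4 (0.08 log units; within the scatter)) or from furan-2-yl (a 1.1-fold lower number from compound 2 to compound 4 (0.03 log units; within the scatter)), since both steps lie within the scatter. With both rings now seen at both attachment points, neither the oxygen ring alone nor the 3-yl attachment alone goes with the higher number: it appears only where the two coincide, in compound 3.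

No measurement shown gives a reason for this single exception. From the compounds shown here alone, whether a phenyl ring, an amine or a carboxylic acid on this same carbon would keep the number as low also remains open.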